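The source may hold more compounds than are shown below. What is called first, only, known or untested is meant among the compounds shown, and "the series" means these compounds.

Compound 1 `CCOC(=O)c1c(C)[nH]c(=O)c(C#N)c1-c1ccccc1` is the point of departure. In a functional assay on A549 cells (Homo sapiens) for inhibition, read by MTT assay, with a stated time of 24 h (on this read-out lower numbers stand for stronger inhibition and higher numbers for weaker inhibition), compound 1 gives > 100000 nM, which is a limit of the assay and not a number. Compound 2 `CCOC(=O)c1c(C)[nH]c(=O)c(C#N)c1-c1ccc([N+](=O)[O-])cc1` gives > 100000 nM in this assay, again a limit. Compound 3 `CCOC(=O)c1c(C)[nH]c(=O)c(C#N)c1-c1ccc(C#N)cc1` gives > 100000 nM in this assay, also a limit. The steps a step that the two limits leave unreadable from compound 1 to compound 2, a step that the two limits leave unreadable from compound 1 to compound 3 and a step that the two limits leave unreadable from compound 2 to compound 3 cannot be read because of the limit of > 100000 nM in this assay, at which 3 of the 3 values shown sit. Compound 4 `CCOC(=O)c1c(C)[nH]c(=O)c(C#N)c1-c1ccccc1Cl` differs from compound 1 by chloro in place of hydrogen on an aromatic carbon. Among the compounds with values here, none of the measured steps carries a readable size, so no measured step bears on this change. Compound 4 is therefore expected to sit at the limit as well, and the expected step is a number no higher from compound 1 to compound 4 (the limit leaves the size open). The estimate for compound 4 in this assay is 100000 nM, within a range from 30000 nM to 300000 nM.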

Compound 4, half-maximal inhibitory concentration: 25000 nM
Compound 4: the middle estimate sits 4.0-fold (0.60 log units) above what was measured; the whole stated range lies above it.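

In this assay, within the data shown here, chloro on an aromatic carbon ortho to a large group gives the only readable step so far: an at least 4.0-fold lower number from compound 1 to compound 4 (0.60 log units; beyond the scatter). This step is only a bound, as the value of compound 1 is a limit of the assay and not a number. The earlier steps cannot be read, because they rest on limits: the limit of > 100000 nM in this assay, at which 3 of the 4 values shown sit.

The compounds shown leave open whether a methoxy group or an amine at this place would also lower the number. They also leave open whether chloro on another carbon of the ring would do so.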